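Moving a Hydroxyl Group Around the Ring of Compound 2

The source may hold more compounds than are shown below. What is called first, only, known or untested is meant among the compounds shown, and "the series" means these compounds.

Three related compounds have been measured in a functional assay on HL-60 cells (Homo sapiens) for cytotoxicity, read by ELISA, with a stated time of 2 days; a higher number here means a weaker inhibitor, a lower number a stronger inhibitor. Compound 2 `Oc1ccccc1-c1cc(-c2ccccc2)nc(-c2ccco2)c1` gives 1900 nM, the lowest of the three numbers. Compound 1 `Oc1ccc(-c2cc(-c3ccccc3)cc(-c3cccnc3)n2)cc1` gives 4100 nM, and compound 3 `Oc1cccc(-c2cc(-c3ccccc3)nc(-c3ccccc3)c2)c1` gives 13500 nM, both higher by more than the usual scatter.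

Compound 4 `Oc1ccc(-c2cc(-c3ccccc3)nc(-c3ccco3)c2)cc1` has the same atoms as compound 2, joined differently: 4-hydroxyphenyl in place of 2-hydroxyphenyl on an aromatic carbon. It has 4-hydroxyphenyl in place of 2-hydroxyphenyl on an aromatic carbon, opposite the ring nitrogen. For the measured compounds named here, no measured pair isolates this swap. Compound 1 also carries a 4-hydroxyphenyl group and gives 4100 nM, but it differs elsewhere too. A small shift towards weaker inhibition is therefore expected, a 1.6-fold higher number from compound 2 to compound 4 (0.20 log units; within the scatter). For compound 4 the estimate is 3000 nM, with an expected range of 900 nM to 10000 nM.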

Compound 4, half-maximal inhibitory concentration: 13700 nM
The estimate for compound 4 lay 4.6-fold (0.66 log units) below the measured number, outside the stated range (above it).
By their numbers in this assay, from the lowest: compound 2; then compound 1; then compounds 3 and 4 (each within the scatter of the next).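

With the same atoms and the same counted donor and acceptor, moving the hydroxyl from 2-hydroxyphenyl to 4-hydroxyphenyl on this carbon opposite the ring nitrogen gives a 7.2-fold higher number from compound 2 to compound 4 (0.86 log units; beyond the scatter) in this assay. For the compounds shown here, this is the first direct comparison at this position, and it shows that where the hydroxyl sits on this phenyl ring matters, not just whether it is present. Nothing available here explains the difference.

The compounds shown leave open whether the hydroxyl itself is needed, as a methoxy group or an amine in its place would test.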